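Carbamate replacement on the ring-carbon substituent of compound 2

The source may report more compounds than this note shows. Statements on the series, on what has been measured and on what is new or still open speak of the compounds shown alone.

Compound 2 `CN(C(=O)c1ccccc1)C1CN[C@H](C(=O)N2CC=C(c3ccccc3)CC2)[C@@H](C(=O)NO)C1` gives 12 nM in an assay on isolated protein for inhibition of disintegrin and metalloproteinase domain-containing protein 10 (Homo sapiens) (on this read-out lower numbers stand for stronger inhibition and higher numbers for weaker inhibition), the lowest of the two numbers recorded so far; its nearest neighbour is compound 1 `O=C(NO)[C@H]1CC(CC(=O)N2CCCC2)CN[C@@H]1C(=O)N1CC=C(c2ccccc2)CC1`, which gives 17 nM. Among the compounds with values here, the single measured step, a 1.4-fold lower number from compound 1 to compound 2 (0.15 log units; within the scatter), exchanges the substituent on the saturated ring carbon and stays within the scatter. Compound 3 `CC(C)OC(=O)N(C)C1CN[C@H](C(=O)N2CC=C(c3ccccc3)CC2)[C@@H](C(=O)NO)C1` differs from compound 2 by isopropoxy in place of phenyl on a carbonyl carbon. This change sits on the same substituent that the measured step varied, so that step is the only one bearing on it; since it lay within the scatter, it gives no direction for the new substituent on the carbonyl carbon. No step beyond the scatter is therefore expected, a 1.3-fold higher number from compound 2 to compound 3 (0.10 log units; within the scatter). Compound 3 is estimated at 15 nM in this assay, with a range from 5 nM to 45 nM.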

Compound 3, half-maximal inhibitory concentration: 11 nM
The estimate for compound 3 lay 1.4-fold (0.13 log units) above the measured number, within the range that was stated.
By their numbers in this assay, from the lowest: compounds 3, 2 and 1 (each within the scatter of the next).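

In this assay the carbonyl carbon accepts isopropoxy as well as phenyl with a 1.1-fold lower number from compound 2 to compound 3 (0.04 log units; within the scatter) as the result, so among the compounds shown, the six-membered aromatic ring of carbon only is not required there for a number in this range. The broader exchange on the saturated ring carbon gives a 1.5-fold lower number from compound 1 to compound 3 (0.19 log units; within the scatter) and also stays within the scatter, which means that the three substituents shown at this position cannot be told apart on this read-out. No evidence on hand bears on this result.

From the compounds shown here alone, all three substituents carry a carbonyl, so it remains open whether any change at this position can move the number beyond the scatter. A free amine or a carboxylic acid on the saturated ring carbon, or a longer alkoxy chain on the carbonyl carbon, would put this to the test.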